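Lengthening the Ester Chain from Propyl to Pentyl

This account rests on a few compounds, and the source may have more. Where it says the series, first, only, none or still open, it means among the compounds named here.

Compound 1 `O=C(O)c1cc(N2C(=O)C3=C(CCCC3)C2=O)c(F)cc1Cl`: 1000 nM
Compound 2 `CCCOC(=O)c1cc(N2C(=O)C3=C(CCCC3)C2=O)c(F)cc1Cl`: 33.1 nM
Compound 3 `CCCOC(=O)c1cc(N2C(=O)C3=C(CCCC3)C2=O)ccc1Cl`: 1120 nM

In a functional assay on the whole organism for inhibition, with Scenedesmus acutus as the target (a higher number here means a weaker inhibitor, a lower number a stronger inhibitor), compound 3 gives 1120 nM, which lies within the usual scatter of compound 1. It stands far from compound 2, with a 34-fold higher number from compound 2 to compound 3 (1.53 log units; beyond the scatter), a step that came with hydrogen in place of fluoro on an aromatic carbon.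

Compound 4 `CCCCCOC(=O)c1cc(N2C(=O)C3=C(CCCC3)C2=O)ccc1Cl` keeps that hydrogen and differs only in its chain: ethyl in place of hydrogen on a saturated chain carbon, three bonds along the chain from an oxygen next to a carbonyl group. Propyl thus becomes pentyl. The closest evidence is a 30-fold lower number from compound 1 to compound 2 (1.48 log units; beyond the scatter), where propyl took the place of hydrogen on an oxygen next to a carbonyl group. Among the measured compounds shown here, that large step installed the chain rather than lengthening it, and no measured step shows what lengthening does. Its size therefore cannot simply be carried over. A small move toward a lower number is expected, possibly none beyond the scatter. The expected change is a 1.4-fold lower number from compound 3 to compound 4 (0.15 log units; within the scatter), an estimate only. For compound 4 the estimated value is 800 nM, with an expected range from 250 nM to 2500 nM.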

Compound 4, half-maximal inhibitory concentration: 4470 nM
Compound 4: the middle estimate sits 5.6-fold (0.75 log units) below what was measured, and the stated range ends below it.
By their numbers in this assay, from the lowest: compound 2; then compounds 1 and 3 (each within the scatter of the next); then compound 4.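

In this assay the step is a 4.0-fold higher number from compound 3 to compound 4 (0.60 log units; beyond the scatter), so going from propyl to pentyl gives a weaker inhibitor, a modest change but one beyond the scatter. Among the compounds shown here, the earlier compounds showed only what installing a propyl chain on the oxygen did, with a 30-fold lower number from compound 1 to compound 2 (1.48 log units; beyond the scatter), whereas this is the first view of chain length itself, and here the longer chain goes with a higher number. For the compounds shown here, this holds for the one pair that shows lengthening, where the aromatic carbon carries hydrogen.

On these data alone, two chain lengths cannot show how the number changes from one length to the next, so a butyl or an ethyl chain remains open, as does a pentyl chain with fluoro in place of that hydrogen. Nothing measured here explains why the longer chain gives the weaker inhibitor.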